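This account rests on a few compounds, and the source may have more. Where it says the series, first, only, none or still open, it means among the compounds named here.

Measured in a physicochemical assay for lipophilicity, measured as octanol-water partition; on this read-out lower numbers stand for lower lipophilicity and higher numbers for higher lipophilicity:
- compound 1 `CC(C)[C@@H]1CC[C@@H](C)C[C@H]1OC(=O)c1ccccc1`: 4.82
- compound 2 `CC(C)[C@@H]1CC[C@@H](C)C[C@H]1OC(=O)c1ccccc1Cl`: 5.34

Of these two, compound 2 holds the higher number, 5.34. Within the data shown here, the single measured step, chloro in place of hydrogen on an aromatic carbon, is a number 0.52 log units higher from compound 1 to compound 2 (beyond the scatter).

Compound 3 `Cc1ccccc1C(=O)O[C@@H]1C[C@H](C)CC[C@H]1C(C)C` has not yet been measured. Its difference from compound 2 is methyl in place of chloro on an aromatic carbon, ortho to a large group. Among the measured compounds shown here, no measured step covers this exchange directly. The nearest evidence is a number 0.52 log units higher from compound 1 to compound 2 (beyond the scatter), which involves a change at the same place. Compound 3 also carries a substituent there, so it is expected to retain most of that rise, and this assay should show little change. The estimated change is a number 0.09 log units lower from compound 2 to compound 3 (within the scatter). For compound 3 the expected value is 5.25, with an estimated range from 4.95 to 5.55.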

Compound 3, partition coefficient: 5.29
Compound 3: middle estimate off by 0.04 log units, on the low side, within the range that was stated.
By their numbers in this assay, from the lowest: compound 1; then compounds 3 and 2 (each within the scatter of the next).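

In this assay the aromatic carbon ortho to a large group now carries a second kind of substituent, and methyl in place of hydrogen gives a number 0.47 log units higher from compound 1 to compound 3 (beyond the scatter), which runs the same way as chloro in place of hydrogen, a number 0.52 log units higher from compound 1 to compound 2 (beyond the scatter). Exchanging the two substituents gives a number 0.05 log units lower from compound 2 to compound 3 (within the scatter), so at this position this assay does not separate chloro from methyl. Nothing available explains this match.

The compounds shown leave open whether a hydroxyl, an amine or a carboxylic acid at this place would also raise the number from that of compound 1 or would lower it. They also leave open whether methyl and chloro would match in the same way on another carbon of the aromatic ring.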